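A few compounds are considered here, and "the series" means these few. Any claim that something is new, unique, unknown or untested is made for them only; others in the source may bear on it.

Within the data shown here, in a functional assay on MDA-MB-468 cells (Homo sapiens) for inhibition, read by sulforhodamine B assay, with a stated time of 48 h (a lower number here means a stronger inhibitor of growth, a higher number a weaker inhibitor of growth), compound 2 (`Cc1cc(O)ccc1C1=NN(c2ccc(S(C)(=O)=O)cc2)C(=O)CC1`) gives 11000 nM, the higher of the two numbers so far, and compound 1 (`Cc1ccc(C2=NN(c3ccc(S(C)(=O)=O)cc3)C(=O)CC2)cc1`) gives 1230 nM on the same shared core. The next change leads to compound 3 (`CCc1ccc(C2=NN(c3ccc(S(C)(=O)=O)cc3)C(=O)CC2)cc1`) and is 4-ethylphenyl in place of 4-hydroxy-2-methylphenyl on a carbon with a double bond to nitrogen, with 4-ethylphenyl in place of 4-hydroxy-2-methylphenyl on a carbon with a double bond to nitrogen. Among the measured compounds shown here, only one measured step bears on this: an 8.9-fold higher number from compound 1 to compound 2 (0.95 log units; beyond the scatter), a modest change for 4-hydroxy-2-methylphenyl in place of 4-methylphenyl. The new change removes that same group, so a step of similar size in the opposite direction is expected, although the ethyl group itself has not been tested. The expected step is a 7.3-fold lower number from compound 2 to compound 3 (0.87 log units; beyond the scatter), toward a lower number. For compound 3 the estimated value is 1500 nM, with an expected range from 500 nM to 4500 nM in this series.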

Compound 3, concentration for 50% growth inhibition: 3750 nM
Compound 3: the middle estimate sits 2.5-fold (0.40 log units) below what was measured; the range from low to high includes it.
By their numbers in this assay, from the lowest: compound 1; then compound 3; then compound 2.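

In this assay, 4-ethylphenyl in place of 4-hydroxy-2-methylphenyl gives a 2.9-fold lower number from compound 2 to compound 3 (0.47 log units; beyond the scatter), so a group without the hydroxyl recovers only part of the gap to compound 1. The position is also sensitive to a small change in the alkyl group alone: methyl in place of hydrogen on the saturated chain carbon gives a 3.0-fold higher number from compound 1 to compound 3 (0.48 log units; beyond the scatter), a change that involves no hydroxyl group and puts compound 3 between compound 1 and compound 2. Nothing at hand accounts for either shift.

The compounds shown do not separate the contributions of the hydroxyl and the ring methyl in compound 2, which a 4-hydroxyphenyl group would help to resolve. From the compounds shown here alone, it also remains open whether a longer chain such as propyl, or a methoxy group or an amine in the same place, would continue this trend or depart from it.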